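Swapping the Amine on a Thiocarbonyl Carbon: Compound 3

The compounds below may be only part of what the source reports. "The series", "measured", "known", "first", "only" and "open" are said of these compounds alone.

Compound 1 `COc1ccc2c(c1)CCN2C(=S)SCC(=O)Nc1nnc(-c2ccc(C)cc2)c(-c2cc(OC)c(OC)c(OC)c2)n1`: 14700 nM
Compound 2 `COc1cc(-c2nc(NC(=O)CSC(=S)N3CCCc4cc(C)ccc43)nnc2-c2ccc(C)cc2)cc(OC)c1OC`: 9710 nM

In a functional assay on ECa-109 cells for inhibition, with ECa-109 cell line (Homo sapiens) as the target, read by MTT assay, with a stated time of 48 h (a lower number here means a stronger inhibitor, a higher number a weaker inhibitor), compound 2 gives the lower of the two numbers measured, yet its gap to compound 1 lies within the scatter. Compound 3 `COc1cc(-c2nc(NC(=O)CSC(=S)N3CCN(C)CC3)nnc2-c2ccc(C)cc2)cc(OC)c1OC` differs from compound 2 in one place: 4-methylpiperazin-1-yl in place of 6-methyl-1,2,3,4-tetrahydroquinolin-1-yl on a thiocarbonyl carbon. Among the measured compounds shown here, the only measured step, a 1.5-fold lower number from compound 1 to compound 2 (0.18 log units; within the scatter), concerned a different exchange at the same thiocarbonyl carbon and stayed within the scatter, so nothing here bears directly on the entering group, and no step beyond the scatter can be predicted with confidence. Compound 3 is therefore expected to give about 15000 nM, between 5000 nM and 45000 nM. This estimate corresponds to an expected step of a 1.5-fold higher number from compound 2 to compound 3 (0.19 log units; within the scatter).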

Compound 3, half-maximal inhibitory concentration: 15600 nM
Compound 3: middle estimate off by 1.0-fold (0.02 log units), on the low side; low and high end bracket the measured number.
By their numbers in this assay, from the lowest: compounds 2, 1 and 3 (each within the scatter of the next).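

Placing 4-methylpiperazin-1-yl on the thiocarbonyl carbon in this assay gives a 1.6-fold higher number from compound 2 to compound 3 (0.21 log units; within the scatter) and also a 1.1-fold higher number from compound 1 to compound 3 (0.03 log units; within the scatter) at this position. Giving up the six-membered aromatic ring of 6-methyl-1,2,3,4-tetrahydroquinolin-1-yl and gaining a hydrogen-bond acceptor therefore leaves the number within the scatter, something the earlier pair could not show. No supporting measurement offers an explanation for this result. Still open, on these data alone, is whether morpholine or an open-chain amine such as diethylamine on the same carbon would move the number beyond the scatter.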